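The source may report more compounds than this note shows. Statements on the series, on what has been measured and on what is new or still open speak of the compounds shown alone.

Measured compounds:
compound 1 `COC(=O)C[C@H](O)[C@H]1O[C@@H](c2ccccc2)[C@H](O)[C@H]1O` — "not active" (no number reported)
compound 2 `O=C1C[C@@H](O)[C@@H]2O[C@H](c3ccccc3)[C@@H](O)[C@@H]2O1` — "not active" (no number reported)
compound 3 `O=C1C=C[C@@H]2O[C@H](c3ccccc3)[C@@H](O)[C@@H]2O1` — 19000 nM

In a functional assay on CCRF-CEM cells (Homo sapiens) for antiproliferative activity, read by sulforhodamine B assay, with a stated time of 48 h (a higher number here means a weaker inhibitor, a lower number a stronger inhibitor), compound 1 gives "not active" (no number reported). Compound 2 likewise gives "not active" (no number reported) in this assay. For the measured compounds named here, compound 3 is the only member of the series with a number in this assay, where compound 3 gives 19000 nM. Compounds 1 and 2 give no number, so nothing more can be said about their standing relative to compound 3. Compound 4 `O=C1C=C[C@H]2O[C@@H](c3ccccc3)[C@H](O)[C@H]2O1` is not yet measured. Compound 4 differs from compound 3 as follows: the two compounds have the same atoms and bonds and differ only in configuration as drawn: 4 of 4 stereo elements differ (all stereocentres are inverted: mirror images); a stereocentre at a saturated ring carbon is drawn S in compound 3 and R in compound 4; a stereocentre at a saturated ring carbon is drawn R in compound 3 and S in compound 4; a stereocentre at a saturated ring carbon is drawn R in compound 3 and S in compound 4; a stereocentre at a saturated ring carbon is drawn S in compound 3 and R in compound 4. Going by the values given here, no step between two measured compounds is available, so the size of this kind of change is not anchored. A mirror-image pair can give the same reading or a quite different one. With compound 3 already weak, a small step leaning toward weaker, or none beyond the scatter, is expected: a 1.5-fold higher number from compound 3 to compound 4 (0.17 log units; within the scatter). Compound 4 is accordingly estimated at 28000 nM in this assay, within a range of 8000 nM to 100000 nM. A reading of no activity with no number is also a real possibility for compound 4.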

Compound 4, half-maximal inhibitory concentration: 24000 nM
For compound 4 the middle estimate is 1.2-fold (0.07 log units) above the measured one, within the range that was stated.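

In this assay, for the compounds shown here, inverting every stereocentre gives a 1.3-fold higher number from compound 3 to compound 4 (0.10 log units; within the scatter), the first step that can be read. At this weak level, the sense of configuration as a whole therefore does not separate the mirror-image pair in this read-out, which answers what the compounds without a number could not. The comparison is a clean one, with nothing but configuration in play: the fact that compounds 3 and 4 differ only in the configuration as drawn

Only the full mirror image is shown, so the effect of inverting one stereocentre or some of them, which would give a diastereomer rather than a mirror image, remains open. Also open, going by these compounds, is whether this indifference to configuration would persist in a stronger compound, or with an amine, a carboxylic acid or a longer chain in place of the phenyl group.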